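Replacing an ester with an alcohol in compound 4

A few compounds are considered here, and "the series" means these few. Any claim that something is new, unique, unknown or untested is made for them only; others in the source may bear on it.

Measured in a functional assay on A2780 cells (Homo sapiens) for antiproliferative activity, read by sulforhodamine B assay, with a stated time of 48 h; on this read-out lower numbers stand for stronger inhibition of growth and higher numbers for weaker inhibition of growth:
- compound 1 `CC(C)(C)[Si](C)(C)O[C@@H]1CCCO[C@@H]1COCC(=O)O`: > 100000 nM
- compound 2 `C=CCOC[C@H]1OCCC[C@H]1O[Si](C)(C)C(C)(C)C`: 15000 nM
- compound 3 `COC(=O)/C=C/OC[C@H]1OCCC[C@H]1O[Si](C)(C)C(C)(C)C`: 30000 nM

The entry for compound 1, > 100000 nM, is a limit of the assay and not a number. That leaves two true numbers in this assay. Compound 3 gives 30000 nM and compound 2 gives 15000 nM, and the comparison, a 2.0-fold higher number from compound 2 to compound 3 (0.30 log units; within the scatter), does not separate them.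

Compound 4 `CC(C)(C)[Si](C)(C)O[C@@H]1CCCO[C@@H]1CO/C=C/CO` has not yet been measured. It carries hydroxymethyl in place of methoxycarbonyl on a double-bonded chain carbon bound to a double-bonded chain carbon.

Within the data shown here, no measured step makes this exact exchange. The closest is a 2.0-fold higher number from compound 2 to compound 3 (0.30 log units; within the scatter), which swaps allyl for 2-(methoxycarbonyl)ethenyl on the same oxygen and stays within the scatter. The larger steps, an at least 6.6-fold lower number from compound 1 to compound 2 (0.82 log units; beyond the scatter) and an at least 3.3-fold lower number from compound 1 to compound 3 (0.52 log units; beyond the scatter), both remove the carboxy group, which compound 4 also lacks. They start from a limit, so they give only a lower bound on their size. Taken together, these steps suggest that compound 4 should stay with the non-acid compounds in this assay.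

The expected result is a 1.2-fold lower number from compound 3 to compound 4 (0.08 log units; within the scatter), so no change beyond the scatter is anticipated. Compound 4 is estimated at 25000 nM. The expected range for compound 4 runs from 8000 nM to 80000 nM.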

Compound 4, concentration for 50% growth inhibition: > 100000 nM
Compound 4: no number, only a limit (the forecaster's own chance of this, stated with the estimate: 20%); middle value at least 4.0-fold (0.60 log units) from the limit.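

In this assay compound 4 gives > 100000 nM, which is a limit of the assay and not a number. On a double-bonded chain carbon bound to a double-bonded chain carbon, hydroxymethyl in place of methoxycarbonyl proves to be a change that can be seen, with an at least 3.3-fold higher number from compound 3 to compound 4 (0.52 log units; beyond the scatter), and the 3-hydroxyprop-1-en-1-yl group in place of allyl on the same oxygen gives an at least 6.6-fold higher number from compound 2 to compound 4 (0.82 log units; beyond the scatter), whereas the earlier exchange at this oxygen, a 2.0-fold higher number from compound 2 to compound 3 (0.30 log units; within the scatter), had separated nothing. Until now only compound 1, with its carboxymethyl group, had sat at this limit; compound 4 shows that a compound without a carboxy group can sit there too, and the step between these two cannot be read, as both entries are limits: the limit of > 100000 nM in this assay, at which 2 of the 4 values shown sit.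

The compounds shown leave open how far past the limit compound 4 lies, and whether an amine or a methyl ether in place of hydroxymethyl at this place would bring back a readable number. They also do not tell whether the result depends on the double bond, as a saturated chain ending in hydroxymethyl is not among them.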